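Benzyl for Isopropyl, Repeated on the Better Core

The source may report more compounds than this note shows. Statements on the series, on what has been measured and on what is new or still open speak of the compounds shown alone.

Of the compounds shown here, three sharing one core have been tested in a functional assay for inhibition, tested at 100 uM; a higher number here means more inhibition at the concentration tested (going by the name of the read-out), a lower number less inhibition. Compound 1 `COC(=O)[C@H]1N=C(SC(C)C)[C@H]2C(=O)N(c3ccccc3)C(=O)[C@H]21` gives 72%. Compound 2 `COC(=O)[C@H]1N=C(SCc2ccccc2)[C@H]2C(=O)N(c3ccccc3)C(=O)[C@H]21` differs from it by benzyl in place of isopropyl on a sulfur and gives 76%; the step of a number 4 percentage points higher from compound 1 to compound 2 (within the scatter). Compound 3 `COC(=O)[C@@H]1N=C(SC(C)C)[C@H]2C(=O)N(c3ccccc3)C(=O)[C@H]21` has the same atoms and bonds as compound 1, but (the two compounds have the same atoms and bonds and differ only in configuration as drawn: 1 of 3 stereo elements differ; a stereocentre at a saturated ring carbon is drawn S in compound 1 and R in compound 3). In this assay compound 3 gives 89%. The step of a number 17 percentage points higher from compound 1 to compound 3 (beyond the scatter) is the one clear difference among the three, and it rests only on (the fact that compounds 1 and 3 differ only in the configuration as drawn). Compound 3 stands highest, with both compound 2 and compound 1 beyond the scatter below it.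

Compound 4 `COC(=O)[C@@H]1N=C(SCc2ccccc2)[C@H]2C(=O)N(c3ccccc3)C(=O)[C@H]21` is not yet measured. It carries benzyl in place of isopropyl on a sulfur, the same change that was made from compound 1 to compound 2, now on the core of compound 3 with its own drawn configuration. The place of the change reads the same in both pairs. The first time, the step was within the scatter, as a number 4 percentage points higher from compound 1 to compound 2 (within the scatter) shows. A similarly small step is expected here, a number 2 percentage points higher from compound 3 to compound 4 (within the scatter). Compound 4 is therefore expected to give about 91%, most plausibly between 80% and 98%.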

Compound 4, a percentage reported as inhibition, at one concentration (the size of the read-out at that concentration, not a potency): 98%
Estimate against measurement, compound 4: 7 percentage points below, and the stated range covers the measured number.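

In this assay, benzyl in place of isopropyl on a sulfur again gives only a small step, a number 9 percentage points higher from compound 3 to compound 4 (within the scatter), and the change behaves alike on the two cores: the same change on two cores in this assay, a number 4 percentage points higher (within the scatter) from compound 1 to compound 2 and a number 9 percentage points higher (within the scatter) from compound 3 to compound 4, 5 percentage points apart, within the scatter of two such steps. The clear gap in this set stays with the drawn configuration, seen here as a number 22 percentage points higher from compound 2 to compound 4 (beyond the scatter), and it appears with benzyl as it did with isopropyl: the fact that compounds 2 and 4 differ only in the configuration as drawn. For the compounds shown here, this shows only that the change carried over between these two cores, in one assay and at one concentration; it does not show that benzyl and isopropyl are truly equal, that the two small steps are identical, or that the same would hold on any other core.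

The compounds shown leave open what other groups on the sulfur would do, such as a longer chain, an amine or a carboxylic acid. They also leave open how the other stereo elements bear on inhibition, and how these compounds would compare at lower concentrations.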